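The source may report more compounds than this note shows. Statements on the series, on what has been measured and on what is new or still open speak of the compounds shown alone.

In a functional assay on HCT-116 cells (Homo sapiens) for inhibition, read by colorimetric assay, with a stated time of 3 days (a higher number here means a weaker inhibitor, a lower number a stronger inhibitor), two compounds have been measured so far. Compound 1 `O=C(CCCCCCNC(=O)C(O)(O)C(F)(F)F)Nc1nc(-c2ccccc2)c(-c2ccccc2)s1` gives 29900 nM, while compound 2 `O=C(CCCCCCNC(=O)C(O)(O)C(F)(F)F)Nc1ncc(-c2ccccc2)s1` gives 2660 nM, the lower of the two numbers and so the stronger result. Compound 3 `Cc1nc(NC(=O)CCCCCCNC(=O)C(O)(O)C(F)(F)F)sc1-c1ccccc1` differs from compound 2 by a single change: methyl in place of hydrogen on an aromatic carbon. In words, this is methyl in place of hydrogen on an aromatic carbon, the same carbon that carries phenyl in compound 1. Going by the values given here, the only measured step that bears on this is an 11-fold lower number from compound 1 to compound 2 (1.05 log units; beyond the scatter), which is large and beyond the scatter. Methyl is much smaller than the phenyl involved in that step, so only a small rise in the number is expected, one that may not exceed the scatter. The expected step is a 1.5-fold higher number from compound 2 to compound 3 (0.18 log units; within the scatter). For compound 3, the estimated value is 4000 nM, within an expected range of 1800 nM to 11000 nM.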

Compound 3, half-maximal inhibitory concentration: 10100 nM
Estimate against measurement, compound 3: 2.5-fold (0.40 log units) below, and the stated range covers the measured number.
By their numbers in this assay, from the lowest: compound 2; then compound 3; then compound 1.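

In this assay, the aromatic carbon next to the ring nitrogen responds even to the smallest carbon group: methyl in place of hydrogen gives a 3.8-fold higher number from compound 2 to compound 3 (0.58 log units; beyond the scatter) and so does not leave the number unchanged. Methyl in place of phenyl on the same carbon gives a 3.0-fold lower number from compound 1 to compound 3 (0.47 log units; beyond the scatter). Compound 3 thus stands between compound 2 and compound 1, so across these three compounds the number rises in the order hydrogen, methyl, phenyl. Nothing measured here explains that order.

The compounds shown leave open whether this order depends only on the number of heavy atoms in the group, as a fluorine, a methoxy group, an amine or an ethyl group on this carbon could test. They also leave open whether the same order would hold if the ring atom that bears a phenyl group carried something else, such as a pyridine ring.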